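The source may hold more compounds than are shown below. What is called first, only, known or untested is meant among the compounds shown, and "the series" means these compounds.

Measured so far:
Compound 1, `O=C(Nc1ccc(Sc2nc3ccccc3s2)cc1)c1ccccc1` — in an assay for inhibition of HSP60/HSP10 (Homo sapiens), with a stated time of 60 min (a lower number here means a stronger inhibitor, a higher number a weaker inhibitor), compound 1 gives > 100000 nM.
Compound 2, `O=C(Nc1ccc(Sc2nc3ccccc3s2)c(Cl)c1)c1cc(Br)ccc1O` — in this assay compound 2 gives > 100000 nM.

Both of these values are limits of the assay rather than numbers. For compound 2 the reading is a limit, so the only thing known is that its inhibition did not reach the range the assay can resolve. For the measured compounds named here, compound 2 therefore stands at the limit of > 100000 nM in this assay, at which 2 of the 2 values shown sit, and there is no measured step between compounds that differ in one place on which a trend could rest. Compound 1 and compound 2 differ in more than one place, and their two readings show only that neither produced a measurable inhibition.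

The unmeasured compound 3, `O=C(Nc1ccc(Sc2nc3ccccc3s2)cc1)c1cc(Br)ccc1O`, differs from compound 2 by hydrogen in place of chloro on an aromatic carbon. With both neighbouring readings sitting at the limit, no step beyond the scatter is expected in this assay in either direction, and the most likely outcome is another limit. The expected step is a step that the limit leaves unreadable from compound 2 to compound 3. Compound 3 is estimated at 150000 nM, with a range from 40000 nM to 600000 nM.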

Compound 3, half-maximal inhibitory concentration: > 100000 nM
Compound 3 was reported as a limit; the forecaster's own chance of this, stated with the estimate: 85%; the middle value is on the limit's open side.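

Compound 3 reads as a limit in this assay, as do compound 1 and compound 2, so neither of its steps to those two compounds can be read: the limit of > 100000 nM in this assay, at which 3 of the 3 values shown sit.

The compounds shown leave open whether chloro or hydrogen on the aromatic carbon, or 5-bromo-2-hydroxyphenyl in place of phenyl, makes any difference to inhibition.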